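Trimming the exocyclic amine: compound 3 to compound 4

The compounds below may be only part of what the source reports. "The series", "measured", "known", "first", "only" and "open" are said of these compounds alone.

Measured in a functional assay (Homo sapiens) for inhibition of Nucleic Acid, tested at 100 uM; on this read-out higher numbers stand for more inhibition at the one concentration tested (going by the name of the read-out) and lower numbers for less inhibition:
compound 1, `OCCNc1[nH]ccc2ncnc1-2`, gives 3%
compound 2, `[N-]=[N+]=Nc1[nH]ccc2ncnc1-2`, gives 20%
compound 3, `CNc1[nH]ccc2ncnc1-2`, gives 18%

Compound 3 stands second highest of the three; its gap to compound 2 is within the scatter, while compound 1 lies beyond it, a number 15 percentage points higher from compound 1 to compound 3 (beyond the scatter). Compound 4, `Nc1[nH]ccc2ncnc1-2`, carries the change (hydrogen in place of methyl on a nitrogen on an aromatic ring). Going by the values given here, no measured step removes a methyl from this nitrogen directly; the nearest is the shortening of the chain on that nitrogen, a number 15 percentage points higher from compound 1 to compound 3 (beyond the scatter), and the swap a number 2 percentage points lower from compound 2 to compound 3 (within the scatter). Since that shortening gave only a modest gain and the other step stayed within the scatter, in this assay no step beyond the scatter is expected, a number 2 percentage points higher from compound 3 to compound 4 (within the scatter). Compound 4 is estimated at 20%, range 5% to 35%.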

Compound 4, a percentage reported as inhibition, at one concentration (the size of the read-out at that concentration, not a potency): 60%
Compound 4: the middle estimate sits 40 percentage points below what was measured; the measured number lies above the stated range.
By their numbers in this assay, from the lowest: compound 1; then compounds 3 and 2 (each within the scatter of the next); then compound 4.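

Going by these compounds alone, removing the methyl from this nitrogen in this assay brings a large change (a number 42 percentage points higher from compound 3 to compound 4 (beyond the scatter)), whereas the earlier steps at this position were modest at most. Amino also stands clear of azido (a number 40 percentage points higher from compound 2 to compound 4 (beyond the scatter)) and of the (2-hydroxyethyl)amino group (a number 57 percentage points higher from compound 1 to compound 4 (beyond the scatter)), so among these four compounds only the unsubstituted amino group reaches this level. Nothing available accounts for this jump.

Open, going by these compounds, is how an ethylamino or dimethylamino group would read at this position. Also open, on these data alone, is whether an acetamide on this nitrogen would keep the level of compound 4.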